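The source may hold more compounds than are shown below. What is called first, only, known or untested is meant among the compounds shown, and "the series" means these compounds.

Measured compounds:
Compound 1, `O=C(O)c1cc(-c2cccc(COc3ccc4c(c3)CN(CC3CC3)C4=O)c2)ccc1Cl`, gives 80 nM in an assay on HEK293 cells for positive allosteric modulation of metabotropic glutamate receptor 2 (Rattus norvegicus), read by thallium flux; a lower number here means that less compound is needed, a higher number that more compound is needed for the effect.
Compound 2, `CC(C)N1Cc2cc(OCc3cccc(-c4ccc(Cl)c(C(=O)O)c4)c3)ccc2C1=O`, gives 70 nM in this assay.
Compound 3, `CC(C)CCN1Cc2cc(OCc3cccc(-c4ccc(Cl)c(C(=O)O)c4)c3)ccc2C1=O`, gives 60 nM in this assay.

Compound 1 holds the highest of these three numbers, yet every gap to the others sits within the usual scatter: a 1.1-fold lower number from compound 1 to compound 2 (0.06 log units; within the scatter) and a 1.3-fold lower number from compound 1 to compound 3 (0.12 log units; within the scatter). The remaining pair behaves the same way: a 1.2-fold lower number from compound 2 to compound 3 (0.07 log units; within the scatter). All three compounds share one core and differ only in the group on the amide-type nitrogen in a ring.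

Compound 4, `O=C(O)c1cc(-c2cccc(COc3ccc4c(c3)CN(C3CCCCC3)C4=O)c2)ccc1Cl`, has not been measured. It differs from compound 1 in one place: cyclohexyl in place of cyclopropylmethyl on an amide-type nitrogen in a ring. The three measured steps all swap the group on that same nitrogen, and none of them moved the number beyond the scatter. For the measured compounds named here, no measured compound carries a cyclohexyl there, so the expectation rests on those three steps alone. Accordingly, no step beyond the scatter is expected in this assay: a 1.1-fold lower number from compound 1 to compound 4 (0.06 log units; within the scatter). Compound 4 is estimated at 70 nM, with a range from 30 nM to 170 nM.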

Compound 4, half-maximal effective concentration: 270 nM
For compound 4 the middle estimate is 3.9-fold (0.59 log units) below the measured one; measured number above the stated range.
By their numbers in this assay, from the lowest: compounds 3, 2 and 1 (each within the scatter of the next); then compound 4.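

For the compounds shown here, the group on this amide-type nitrogen can change only so far in this assay: cyclohexyl is the first group here to move the number beyond the scatter, with a 3.4-fold higher number from compound 1 to compound 4 (0.53 log units; beyond the scatter), a 3.9-fold higher number from compound 2 to compound 4 (0.59 log units; beyond the scatter) and a 4.5-fold higher number from compound 3 to compound 4 (0.65 log units; beyond the scatter). Cyclopropylmethyl, isopropyl and isopentyl all stay within the scatter of one another, so the earlier compounds suggested a forgiving position, and cyclohexyl shows that this does not hold for every carbon-only group. Nothing shown here accounts for the rise.

As far as these compounds go, it stays open whether the rise belongs to the six-membered ring itself or to having a ring bound straight to the nitrogen, and cyclobutyl or cyclohexylmethyl there would tell these apart. Also open, from the compounds shown here alone, is whether a ring containing oxygen, such as tetrahydropyranyl, would behave like cyclohexyl.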